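A few compounds are considered here, and "the series" means these few. Any claim that something is new, unique, unknown or untested is made for them only; others in the source may bear on it.

Measured compounds:
compound 1, `O=c1cc(CSC(=S)N2CCCC2)oc2ccccc12`: 35800 nM
compound 2, `COc1ccc2oc(CSC(=S)N(C(C)C)C(C)C)cc(=O)c2c1`: a limit only, > 25000 nM
compound 3, `CC(C)N(C(=S)SCc1cc(=O)c2ccc(Cl)cc2o1)C(C)C`: a limit only, > 25000 nM

Among the measured compounds shown here, in a functional assay on MCF7 cells (Homo sapiens) for antiproliferative activity, read by MTT assay, with a stated time of 72 h (on this read-out higher numbers stand for weaker inhibition and lower numbers for stronger inhibition), compound 1 gives 35800 nM, the only numeric value in the set. For compound 2 the assay reports a limit rather than a number, > 25000 nM. For compound 3 the assay likewise reports only a limit, > 25000 nM. Compound 3 therefore stands at the limit of > 25000 nM in this assay, at which 2 of the 3 values shown sit, and on this read-out nothing separates it from compound 2; compound 1 sits at a weak numeric value of the same order.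

Compound 4, `CC(C)N(C(=S)SCc1cc(=O)c2ccccc2o1)C(C)C`, differs from compound 3 by hydrogen in place of chloro on an aromatic carbon. For the measured compounds named here, no step between measured compounds is available to anchor this change, and both values on the shared core of compound 3 are limits. The step implied by the estimate, a step that the limit leaves unreadable from compound 3 to compound 4, is expected to be none beyond the scatter. Compound 4 is estimated at 30000 nM, with a range from 12000 nM to 80000 nM, and is expected most likely to return again only a limit.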

Compound 4, half-maximal inhibitory concentration: 31700 nM
Compound 4: the middle estimate sits 1.1-fold (0.02 log units) below what was measured, and the stated range covers the measured number.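

In this assay compound 4 gives 31700 nM, the only number among the diisopropylamino compounds shown. This makes one change readable: diisopropylamino in place of pyrrolidin-1-yl on a thiocarbonyl carbon gives a 1.1-fold lower number from compound 1 to compound 4 (0.05 log units; within the scatter), so this pair shows no separation on the read-out. The steps to compound 4 from compound 2 and compound 3 cannot be read, so hydrogen in place of methoxy or chloro on an aromatic carbon has no size, as both starting points are limits: the limit of > 25000 nM in this assay, at which 2 of the 4 values shown sit.

Going by these compounds, whether methoxy or chloro on this aromatic carbon changes the read-out at all remains open. Also open, on these data alone, is how an amine or a carboxylic acid on that carbon, or a longer chain in place of the isopropyl groups on the nitrogen, would read.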